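A few compounds are considered here, and "the series" means these few. Any claim that something is new, unique, unknown or untested is made for them only; others in the source may bear on it.

Three compounds have been measured in an assay on isolated protein for inhibition of acid ceramidase (Homo sapiens), read by LC-MS, with a stated time of 1 h; a lower number here means a stronger inhibitor, a higher number a weaker inhibitor:

Compound 1 `COc1ccc(-c2cn(C(=O)NCCCCc3ccccc3)c(=O)o2)cc1`: 400 nM
Compound 2 `COc1ccccc1-c1cn(C(=O)NCCCCc2ccccc2)c(=O)o1`: 177 nM
Compound 3 `O=C(NCCCCc1ccccc1)n1cc(-c2ccccn2)oc1=O`: 25 nM

Compound 3 stands lowest of the three, with a step of a 16-fold lower number from compound 1 to compound 3 (1.20 log units; beyond the scatter) and a step of a 7.1-fold lower number from compound 2 to compound 3 (0.85 log units; beyond the scatter), while the step of a 2.3-fold lower number from compound 1 to compound 2 (0.35 log units; beyond the scatter) is smaller. Compound 4 `O=C(NCCCCc1ccccc1)n1cc(-c2nccs2)oc1=O` differs from compound 3 by 1,3-thiazol-2-yl in place of pyridin-2-yl on an aromatic carbon. Among the compounds with values here, no measured step swaps one ring type for another in this way, so none bears on it directly; the measured steps only show that the group at this position can move the number strongly. The step of a 1.6-fold higher number from compound 3 to compound 4 (0.20 log units; within the scatter) is therefore expected to be small, slightly toward a higher number. Compound 4 is estimated at 40 nM, in the range 12 nM to 130 nM.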

Compound 4, half-maximal inhibitory concentration: 59 nM
Beside the measured number, compound 4's estimate is 1.5-fold (0.17 log units) below it, within the range that was stated.
By their numbers in this assay, from the lowest: compound 3; then compound 4; then compound 2; then compound 1.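

The 1,3-thiazol-2-yl group shows that a five-membered aromatic ring with 2 hetero atoms can also sit at this position and still give a lower number than either methoxyphenyl group, with a 6.8-fold lower number from compound 1 to compound 4 (0.83 log units; beyond the scatter) and a 3.0-fold lower number from compound 2 to compound 4 (0.48 log units; beyond the scatter). Pyridin-2-yl remains ahead of it, with a 2.4-fold higher number from compound 3 to compound 4 (0.37 log units; beyond the scatter), so the choice between these two rings matters modestly. Nothing available explains this difference. Still open, going by these compounds, is how a pyrimidin-2-yl ring or a methyl group added to the thiazole would change the number.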